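The source may hold more compounds than are shown below. What is called first, only, known or untested is meant among the compounds shown, and "the series" means these compounds.

In a functional assay on HepG2 cells (Homo sapiens) for inhibition, read by sulforhodamine B assay, with a stated time of 74 h (a higher number here means a weaker inhibitor, a lower number a stronger inhibitor), compound 1 `O=C1C=CC2(C=C1)OCC(=O)N2S(=O)(=O)c1ccccc1` gives > 10000 nM, which is a limit and not a number. Compound 2 `O=C1C=CC2(C=C1)OCC(=O)N2S(=O)(=O)c1ccc(N2CCCC2=O)cc1` gives > 10000 nM, also a limit. Compound 3 `O=C1C=CC2(C=C1)OCC(=O)N2S(=O)(=O)c1ccc(OC(F)(F)F)cc1` gives > 10000 nM, again a limit. Compound 4 `O=C1C=CC2(C=C1)OCC(=O)N2S(=O)(=O)c1ccc(C(F)(F)F)cc1` carries trifluoromethyl in place of trifluoromethoxy on an aromatic carbon, para to a large group: trifluoromethyl in place of trifluoromethoxy on an aromatic carbon. The measured steps that bear on this change, a step that the two limits leave unreadable from compound 1 to compound 3 and a step that the two limits leave unreadable from compound 2 to compound 3, have no readable size, so they point in no direction. What remains is the limit of > 10000 nM in this assay, at which 3 of the 3 values shown sit. No clear gain or loss is therefore expected, and the estimated step is a step that the limit leaves unreadable from compound 3 to compound 4. For compound 4 the expected value is 12000 nM, with an estimated range from 4000 nM to 30000 nM.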

Compound 4, half-maximal inhibitory concentration: 750 nM
Estimate against measurement, compound 4: 16-fold (1.20 log units) above; the measured number lies below the stated range.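

In this assay, the place para to a large group proves able to change the result, with an at least 13-fold lower number from compound 3 to compound 4 (1.12 log units; beyond the scatter). Trifluoromethyl also stands apart from the other two groups there, with an at least 13-fold lower number from compound 2 to compound 4 (1.12 log units; beyond the scatter) and an at least 13-fold lower number from compound 1 to compound 4 (1.12 log units; beyond the scatter). The steps among compound 1, compound 2 and compound 3 cannot be read, and limits still dominate the series: the limit of > 10000 nM in this assay, at which 3 of the 4 values shown sit.

Among these compounds, only one group here gives a readable value, so there is no trend to follow yet. Going by these compounds, whether a nitrile, an amine or a carboxylic acid at this place would match trifluoromethyl remains open.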